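Shortening the Hydroxamate Linker on a Pyrazole Carboxamide

The source may hold more compounds than are shown below. What is called first, only, known or untested is meant among the compounds shown, and "the series" means these compounds.

Measured so far:
compound 1, `O=C(CCCCNC(=O)c1cc(-c2ccc(F)cc2)[nH]n1)NO`, > 100000 nM
compound 2, `Cc1ccc(-c2cc(C)n(Cc3ccc(C(=O)NO)cc3)n2)cc1`, 11200 nM
compound 3, `CCc1cc(-c2ccc(F)cc2)n(Cc2ccc(C(=O)NO)cc2)n1`, 16700 nM

All three were tested in a functional assay on A549 cells (Homo sapiens) for antiproliferative activity, read by MTT assay, with a stated time of 96 h; a lower number here means a stronger inhibitor of growth, a higher number a weaker inhibitor of growth. Compound 1 did not reach a measurable number: its result is a limit, > 100000 nM, which means growth inhibition was too weak to quantify within the tested range (the limit of > 100000 nM in this assay, at which 1 of the 3 values shown sits). Compound 2 gives 11200 nM in this assay, and compound 3 gives 16700 nM, so both carry measured values where compound 1 does not.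

Compound 4, `O=C(CCNC(=O)c1cc(-c2ccc(F)cc2)[nH]n1)NO`, has not yet been measured. It differs from compound 1 in one place: hydroxycarbamoyl in place of 2-(hydroxycarbamoyl)ethyl on a saturated chain carbon, two bonds along the chain from an amide-type nitrogen. The shared core of compound 1 is kept, and only the chain that carries the hydroxamic acid is shortened.

For the measured compounds named here, since compound 1 already sits at the limit, no measured step gives guidance on how far the chain length matters here. Compound 4 is expected to remain in the same region, with an expected step of a number no higher from compound 1 to compound 4 (the limit leaves the size open), likely again reported only as a limit. The estimate for compound 4 is 100000 nM, with a range from 30000 nM to 300000 nM.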

Compound 4, concentration for 50% growth inhibition: 46900 nM
For compound 4 the middle estimate is 2.1-fold (0.33 log units) above the measured one; low and high end bracket the measured number.
By their numbers in this assay, from the lowest: compounds 2 and 3 (each within the scatter of the next); then compound 4. At a limit, above all of these: compound 1.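

The value of compound 1, > 100000 nM, is a limit and not a number. For the compounds shown here, with hydroxycarbamoyl in place of 2-(hydroxycarbamoyl)ethyl on a saturated chain carbon, two bonds along the chain from an amide-type nitrogen, this assay shows an at least 2.1-fold lower number from compound 1 to compound 4 (0.32 log units; beyond the scatter), so the length of this chain does affect growth inhibition, which the earlier compounds alone could not show. The true size of the step stays unknown because one end of it is a limit: the limit of > 100000 nM in this assay, at which 1 of the 4 values shown sits.

Two chain lengths on this shared core are too few to define a trend with length. On these data alone, it also remains open whether a still shorter chain, or a carboxylic acid in place of the hydroxycarbamoyl end, would lower the number further or raise it.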